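The source may report more compounds than this note shows. Statements on the series, on what has been measured and on what is new or still open speak of the compounds shown alone.

Of the compounds shown here, three sharing one core have been tested so far, and they differ only in the aryl group attached to the amide carbonyl. Compound 1 `Cc1cccc(C(=O)Nc2cccc(-c3oc4cc(-c5ccc(F)cc5)ccc4c(=O)c3O)c2)c1` gives 8030 nM in a functional assay on HCC1937 cells (Homo sapiens) for antiproliferative activity, read by CCK-8 assay, with a stated time of 72 h; on this read-out lower numbers stand for stronger inhibition and higher numbers for weaker inhibition. Compound 2 `Cc1cc(C(=O)Nc2cccc(-c3oc4cc(-c5ccc(F)cc5)ccc4c(=O)c3O)c2)ccc1F` gives 5420 nM in this assay. Compound 3 `COc1cc(OC)cc(C(=O)Nc2cccc(-c3oc4cc(-c5ccc(F)cc5)ccc4c(=O)c3O)c2)c1` gives 6250 nM in this assay, which places compound 3 second highest of the three numbers, with compound 2 nearest and compound 1 furthest; all three values sit within the scatter of one another, so no order among them can be read.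

Compound 4 `O=C(Nc1cccc(-c2oc3cc(-c4ccc(F)cc4)ccc3c(=O)c2O)c1)c1ccc(-c2ccccc2)cc1` is the next member of the series. Relative to compound 3 the change is 4-phenylphenyl in place of 3,5-dimethoxyphenyl on a carbonyl carbon. The steps already seen at the same carbonyl position, a 1.3-fold lower number from compound 1 to compound 3 (0.11 log units; within the scatter) and a 1.2-fold higher number from compound 2 to compound 3 (0.06 log units; within the scatter), both stayed within the scatter, as did the smaller change a 1.5-fold lower number from compound 1 to compound 2 (0.17 log units; within the scatter). Among the measured compounds shown here, no measured step reaches the size of the swap to a 4-phenylphenyl group, so the expectation rests only on the observation that exchanging the aryl group on the amide carbonyl has so far left the number in this assay essentially unchanged. Compound 4 is therefore expected to give about 6000 nM, between 2500 nM and 15000 nM, a step estimated as a 1.0-fold lower number from compound 3 to compound 4 (0.02 log units; within the scatter) with no movement beyond the scatter.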

Compound 4, half-maximal inhibitory concentration: 44100 nM
The estimate for compound 4 lay 7.4-fold (0.87 log units) below the measured number, and the stated range ends below it.
By their numbers in this assay, from the lowest: compounds 2, 3 and 1 (each within the scatter of the next); then compound 4.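

In this assay the aryl group on the amide carbonyl proves able to shift the number after all: the swap to 4-phenylphenyl gives a 7.1-fold higher number from compound 3 to compound 4 (0.85 log units; beyond the scatter) and an 8.1-fold higher number from compound 2 to compound 4 (0.91 log units; beyond the scatter) and a 5.5-fold higher number from compound 1 to compound 4 (0.74 log units; beyond the scatter) as steps that all lie beyond the scatter. Among the compounds shown here, the tolerance suggested by the earlier compounds therefore covers only the 3-methylphenyl, 4-fluoro-3-methylphenyl and 3,5-dimethoxyphenyl groups, each with a single aromatic ring, and does not extend to this group with two six-membered aromatic rings, so compound 4 stands clearly apart as the weakest of the four. Nothing available explains why this group behaves so differently from the other three.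

With a single compound of this kind, the second ring cannot be separated from the loss of the methoxy groups, nor can the effect of the group's overall shape be told apart from either of these. As far as these compounds go, it also remains open how the number would respond to a pyridine ring, an amine or a carboxylic acid on the aryl group, or to a short alkyl chain in its place, and whether any such group would bring the number down beyond the scatter.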